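The source may hold more compounds than are shown below. What is called first, only, known or untested is meant among the compounds shown, and "the series" means these compounds.

Working notes on the series. In a functional assay on HCT-116 cells (Homo sapiens) for cytotoxicity, read by MTT assay, with a stated time of 48 h, in the presence of a further agent that is not named here (on this read-out lower numbers stand for an effect already at smaller amounts and higher numbers for an effect only at larger amounts of compound), compound 1 (`CCCc1cc(NNC(=O)Nc2cc(Cl)nc(Cl)c2)nc2c1c(C)nn2C`) gives 72200 nM. Compound 3 (`CCCc1cc(NNC(=O)Nc2cc(Cl)nc(Cl)c2)nc2c1cnn2C`) gives 76200 nM, and compound 2 (`Cn1ncc2c(-c3ccc(F)cc3)cc(NNC(=O)Nc3cc(Cl)cc(Cl)c3)nc21`) gives 39100 nM. Both values lie within the usual scatter of compound 1, so its place among the three measured compounds carries no real ranking.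

The step of interest leads to compound 4 (`Cc1nn(C)c2nc(NNC(=O)Nc3cc(Cl)nc(Cl)c3)cc(C3CCCCC3)c12`): cyclohexyl in place of propyl on an aromatic carbon. In words, this is cyclohexyl in place of propyl on an aromatic carbon, opposite the ring nitrogen.

For the measured compounds named here, no measured step tests this change directly. Going by the values given here, the only single-place step, a 1.1-fold higher number from compound 1 to compound 3 (0.02 log units; within the scatter), concerns a methyl rather than the propyl, and it stays within the scatter. Compound 2, with 39100 nM, also carries a ring where compound 1 has propyl, but it differs from compound 1 in more than one place, so it is weak evidence. Even so, nothing measured so far points to a large move, and no step beyond the scatter is expected in this assay. The estimated change is a 1.3-fold lower number from compound 1 to compound 4 (0.12 log units; within the scatter).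

For compound 4 the expected value is 55000 nM, with an estimated range of 22000 nM to 120000 nM.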

Compound 4, half-maximal effective concentration: 38000 nM
Beside the measured number, compound 4's estimate is 1.4-fold (0.16 log units) above it; low and high end bracket the measured number.
By their numbers in this assay, from the lowest: compounds 4, 2, 1 and 3 (each within the scatter of the next).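

With this step, the position opposite the ring nitrogen has its first direct test: in this assay, cyclohexyl in place of propyl gives a 1.9-fold lower number from compound 1 to compound 4 (0.28 log units; within the scatter). For the compounds shown here, the only earlier single-place step, a 1.1-fold higher number from compound 1 to compound 3 (0.02 log units; within the scatter), concerned a methyl elsewhere on the core, so the new step adds that a group of 6 heavy atoms with one six-membered non-aromatic ring, replacing a chain of 3 heavy atoms with no ring, is not separated from propyl by this read-out. No measurement of any other property accompanies the result, so the step stands without an explanation.

From the compounds shown here alone, whether an amine, a carboxylic acid or a longer chain at this position would give a step beyond the scatter remains open, as does a direct comparison of propyl with an aromatic ring such as 4-fluorophenyl on the core of compound 1. Going by these compounds, since each of the four compounds lies within the scatter of the next in this assay, it is also open whether any change at this position moves the number at all.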